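Fluoro in place of chloro, made twice

A few compounds are considered here, and "the series" means these few. Any claim that something is new, unique, unknown or untested is made for them only; others in the source may bear on it.

Compound 1 `S=C(Nc1ccc(Cl)cc1)Nc1nc2ccccc2s1` and compound 2 `Fc1ccc(NC(=S)Nc2nc3ccccc3s2)cc1` share one core, while compound 3 `Fc1ccc2nc(Nc3nc4ccc(Cl)cc4s3)sc2c1` is built on another; the difference between the two cores is not broken down here. In a functional assay on B16-F10 cells (Mus musculus) for cytotoxicity, read by MTT assay, with a stated time of 48 h (on this read-out higher numbers stand for weaker inhibition and lower numbers for stronger inhibition), compound 1 gives only a limit of the assay, > 50000 nM. Compound 2 likewise gives only a limit, > 50000 nM. The change between them is fluoro in place of chloro on an aromatic carbon, and it made a step that the two limits leave unreadable from compound 1 to compound 2, unreadable because both values sit at the limit of > 50000 nM in this assay, at which 2 of the 3 values shown sit. Among the measured compounds shown here, compound 3 gives 41900 nM in this assay, the only number in the set. Compound 4 `Fc1ccc2nc(Nc3nc4ccc(F)cc4s3)sc2c1` is not yet measured; it differs from compound 3 by fluoro in place of chloro on an aromatic carbon, the same kind of change as from compound 1 to compound 2, though here on a ring that is part of a fused or bridged system of two rings, meta to a fused ring and para to a fused ring, rather than para to a large group. The earlier step has no readable size, so the expectation rests on compound 3 alone at 41900 nM. A step of a 1.4-fold higher number from compound 3 to compound 4 (0.16 log units; within the scatter) is expected, with a limit again likely. Compound 4 is estimated near 60000 nM, between 20000 nM and 200000 nM.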

Compound 4, half-maximal inhibitory concentration: 47500 nM
Estimate against measurement, compound 4: 1.3-fold (0.10 log units) above; the range from low to high includes it.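

In this assay, fluoro in place of chloro on the core of compound 3 gives a 1.1-fold higher number from compound 3 to compound 4 (0.05 log units; within the scatter), so the two compounds cannot be told apart on this core. The same kind of change on the core of compound 1 cannot be read, as both values in that pair are limits of the assay: the limit of > 50000 nM in this assay, at which 2 of the 4 values shown sit. With a single readable step, the data do not show whether the change carries from one core to the other.

The compounds shown carry only chloro and fluoro at the changed aromatic carbon. As far as these compounds go, how an amine or a carboxylic acid there would read out in this assay remains open.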